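Amide nitrogen substituent: ring-opened phenylpropyl analogue of compound 1

This account rests on a few compounds, and the source may have more. Where it says the series, first, only, none or still open, it means among the compounds named here.

Measured so far:
Compound 1 `O=C(COc1ccc2[nH]c(=O)c(-c3nccs3)c(CCc3ccccc3)c2c1)NC1(c2ccccc2)CC1` gives 12 nM in an assay on CHO cells for displacement of a labelled ligand from adenosine receptor A2b (Homo sapiens), read by scintillation counting, with a stated time of 60 min; on this read-out higher numbers stand for weaker inhibition and lower numbers for stronger inhibition.
Compound 2 `CC(C)(NC(=O)COc1ccc2[nH]c(=O)c(-c3ccccn3)c(CCc3ccccc3)c2c1)c1ccccc1` has no number in this assay; its entry reads "not determined" (no result reported).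
Compound 3 `COCCCNC(=O)COc1ccc2c(c1)c(CCc1ccccc1)c(-c1ccc(F)cc1F)c(=O)n2C` gives 677 nM in this assay.

Compound 1 stands at the lower of the two numbers; compound 3 sits far higher, well beyond the scatter, and compound 2 adds no number. Among the compounds with values here, no step between measured compounds that differ in one place is available, so the move to compound 4 `CC[C@H](NC(=O)COc1ccc2[nH]c(=O)c(-c3nccs3)c(CCc3ccccc3)c2c1)c1ccccc1` rests on the structural change alone: 1-phenylpropyl in place of 1-phenylcyclopropyl on an amide-type nitrogen. The exchange keeps the heavy-atom count and the phenyl; only the three-membered ring opens and a defined stereocentre appears. A modest step is expected in this assay, if any, most likely toward a somewhat higher number, though a result within the scatter of compound 1 would not surprise. The estimated step is a 1.8-fold higher number from compound 1 to compound 4 (0.26 log units; within the scatter). For compound 4 the expected value is 22 nM, with a range from 6 nM to 80 nM.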

Compound 4, inhibition constant: 20 nM
Beside the measured number, compound 4's estimate is 1.1-fold (0.04 log units) above it; the measured number falls inside the stated range.
By their numbers in this assay, from the lowest: compounds 1 and 4 (each within the scatter of the next); then compound 3.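

In this assay, within the data shown here, the exchange of 1-phenylcyclopropyl for 1-phenylpropyl on the amide-type nitrogen gives a 1.7-fold higher number from compound 1 to compound 4 (0.22 log units; within the scatter) and is the only one-place step so far. The three-membered ring is thus not needed at this position for a value of this order, and the open 1-phenylpropyl group with its defined stereocentre is tolerated. No measured evidence bears on the reason for this.

Still open, as far as these compounds go, is how the mirror-image form of 1-phenylpropyl would read. Also open, from the compounds shown here alone, is whether a longer chain such as 1-phenylbutyl, or an amine on that chain, would hold the value.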